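The source may report more compounds than this note shows. Statements on the series, on what has been measured and on what is new or still open speak of the compounds shown alone.

Compound 1 `O=C(/C=C/c1ccc(O)cc1)c1c(O)cccc1OCc1ccccc1` carries a benzyloxy group on its core. In a functional assay on NCI-H23 cells (Homo sapiens) for antiproliferative activity, read by sulforhodamine B assay (on this read-out higher numbers stand for weaker inhibition of growth and lower numbers for stronger inhibition of growth), compound 1 gives only a limit, > 30000 nM, so its standing is fixed only by the limit of > 30000 nM in this assay, at which 1 of the 2 values shown sits. Among the compounds with values here, compound 2 `CC(C)(C)CCOc1cccc(O)c1C(=O)/C=C/c1ccc(C(=O)O)cc1` is the one compound measured with a number: in this assay compound 2 gives 4770 nM. Within the data shown here, no single step joins these two, as they differ in more than one place, so only their two values can be set side by side. Compound 3 `CC(C)COc1cccc(O)c1C(=O)/C=C/c1ccc(O)cc1` has not yet been measured. It differs from compound 1 in one place: isopropyl in place of phenyl on a saturated chain carbon bound to an oxygen on an aromatic ring. Because compound 1 stands only at the limit of > 30000 nM in this assay, at which 1 of the 2 values shown sits, the size of the step to compound 3 cannot be computed and must be expected rather than read. Compound 3 is estimated at 15000 nM, within 3000 nM to 50000 nM. The expected at least 2.0-fold lower number from compound 1 to compound 3 (0.30 log units; that floor lies within the scatter) would be a moderate gain, though the result may again come back only as a limit.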

Compound 3, concentration for 50% growth inhibition: 3220 nM
Estimate against measurement, compound 3: 4.7-fold (0.67 log units) above; measured number inside the range.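

Within the data shown here, at this position, on a saturated chain carbon bound to an oxygen on an aromatic ring, the change from phenyl to isopropyl gives the first step that can be read in this assay: an at least 9.3-fold lower number from compound 1 to compound 3 (0.96 log units; beyond the scatter). This step lies beyond the scatter, so replacing benzyloxy with isobutoxy on the shared core goes with stronger inhibition of growth, and the ring at the end of this group is not needed for compound 3 to reach a measured number. The true size of the step stays unknown because compound 1 stands only at a limit: the limit of > 30000 nM in this assay, at which 1 of the 3 values shown sits.

From the compounds shown here alone, what an amine, a cyclohexyl group or a longer chain would do at this position stays open. Compound 2 differs from compound 3 in more than one place, so the part played by its carboxylic acid cannot be separated from that of its chain.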